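From ethylamino to isopropylamino on a shared core

A few compounds are considered here, and "the series" means these few. Any claim that something is new, unique, unknown or untested is made for them only; others in the source may bear on it.

Measured in a functional assay on SK-BR-3 cells (Homo sapiens) for antiproliferative activity; a lower number here means a stronger inhibitor, a higher number a weaker inhibitor:
- Compound 1 `CC(C)=CCc1cc(C(=O)Nc2cc3ccc(OCCCN4CCCCC4)c(C)c3oc2=O)ccc1O`: > 50000 nM, a limit of the assay and not a number
- Compound 2 `CCNCCCOc1ccc2cc(NC(=O)c3ccc(O)c(CC=C(C)C)c3)c(=O)oc2c1C`: 720 nM

Going by the values given here, compound 2, at 720 nM, holds the only true number so far. The result for compound 1 is a limit. Compound 3 `CC(C)=CCc1cc(C(=O)Nc2cc3ccc(OCCCNC(C)C)c(C)c3oc2=O)ccc1O` departs from compound 2 at the end of the chain: methyl in place of hydrogen on a saturated chain carbon bound to an amine nitrogen and a saturated chain carbon, which turns ethylamino into isopropylamino.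

Among the compounds with values here, only one measured step bears on this change, and it concerns the same amine group: an at least 69-fold lower number from compound 1 to compound 2 (1.84 log units; beyond the scatter). That step was large, but it exchanged piperidin-1-yl for ethylamino, a much bigger replacement than the present one. It shows that this assay can respond strongly to changes here, yet it does not fix the size of a single added methyl. No shift beyond the scatter is therefore expected, with the wider risk lying towards a weaker result.

The expected change is a 1.4-fold higher number from compound 2 to compound 3 (0.14 log units; within the scatter). For compound 3 the estimated value is 1000 nM, within an expected range of 300 nM to 5000 nM.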

Compound 3, half-maximal inhibitory concentration: 750 nM
For compound 3 the middle estimate is 1.3-fold (0.12 log units) above the measured one; the measured number falls inside the stated range.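

In this assay, the methyl that turns ethylamino into isopropylamino leaves the result within the scatter: a 1.0-fold higher number from compound 2 to compound 3 (0.02 log units; within the scatter). On this saturated chain carbon bound to an amine nitrogen and a saturated chain carbon, the assay therefore tolerates the added methyl, and the large response seen earlier does not carry over to this smaller change. Isopropylamino in place of piperidin-1-yl is also a large step, an at least 66-fold lower number from compound 1 to compound 3 (1.82 log units; beyond the scatter), but its size is only a bound because it rests on a value that is a limit of the assay and not a number: the limit of > 50000 nM in this assay, at which 1 of the 3 values shown sits.

The compounds shown leave open whether the weak result of compound 1 belongs to the ring of piperidin-1-yl or to the absence of a hydrogen on its nitrogen, a question that a dimethylamino group on the same chain would address. Also open, as far as these compounds go, is how much further the amine end can grow, for instance to tert-butylamino or cyclohexylamino, and whether a longer chain carrying the amine would give a similar result.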